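Varying the Amide Substituent: Expectation for Compound 4

A few compounds are considered here, and "the series" means these few. Any claim that something is new, unique, unknown or untested is made for them only; others in the source may bear on it.

Compound 1 `CN(C)C(=O)c1ccc(-c2cc(C3=CC(=O)C=CC3=O)no2)s1`: in a functional assay on PC-3 cells (Homo sapiens) for cytotoxicity, read by XTT assay, with a stated time of 72 h (on this read-out higher numbers stand for weaker inhibition and lower numbers for stronger inhibition), compound 1 gives 7200 nM.
Compound 2 `CN(Cc1ccccc1)C(=O)c1ccc(-c2cc(C3=CC(=O)C=CC3=O)no2)s1`: in this assay compound 2 gives 11000 nM.
Compound 3 `CCN(CC)C(=O)c1ccc(-c2cc(C3=CC(=O)C=CC3=O)no2)s1`: in this assay compound 3 gives 8900 nM.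

Compound 3 holds the second highest of the three numbers. Its nearest neighbour is given by a 1.2-fold lower number from compound 2 to compound 3 (0.09 log units; within the scatter) and its furthest by a 1.2-fold higher number from compound 1 to compound 3 (0.09 log units; within the scatter); both gaps lie within the scatter, so the three compounds cannot be told apart on these numbers.

Compound 4 `O=C1C=CC(=O)C(c2cc(-c3ccc(C(=O)N4CCCC4)s3)on2)=C1` keeps the shared core and changes only the group on the carbonyl: pyrrolidin-1-yl in place of diethylamino on a carbonyl carbon. Going by the values given here, every measured step so far also alters the substituents on the amide nitrogen: a 1.5-fold higher number from compound 1 to compound 2 (0.18 log units; within the scatter), a 1.2-fold higher number from compound 1 to compound 3 (0.09 log units; within the scatter) and a 1.2-fold lower number from compound 2 to compound 3 (0.09 log units; within the scatter). None of these steps left the scatter, even when a phenyl ring entered. The move from diethylamino to pyrrolidin-1-yl is a change of the same kind, so no step beyond the scatter is expected in this assay, in either direction.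

Compound 4 is therefore estimated at 8500 nM, with a range from 4000 nM to 18000 nM. The expected step is a 1.0-fold lower number from compound 3 to compound 4 (0.02 log units; within the scatter).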

Compound 4, half-maximal inhibitory concentration: < 30000 nM
Compound 4: no number, only a limit; the forecaster's own chance of this, stated with the estimate: 5%; the middle value lies beyond the limit too.
By their numbers in this assay, from the lowest: compounds 1, 3 and 2 (each within the scatter of the next).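

In this assay compound 4 gives < 30000 nM as a limit, not a number. Going by these compounds alone, no step to compound 4 from compound 1, compound 2 or compound 3 can be read. Left open is whether pyrrolidin-1-yl on the carbonyl carbon gives a number matching those three compounds or differing from them.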